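This account rests on a few compounds, and the source may have more. Where it says the series, first, only, none or still open, it means among the compounds named here.

The measured compounds:
compound 1, `COc1cc[nH]c1/C=C1\C(=O)Nc2ccc([N+](=O)[O-])c(N3CCC(O)CC3)c21`, gives < 10 nM in a functional assay on RKO cells (Homo sapiens) for antiproliferative activity, read by MTT assay, with a stated time of 5 days; a lower number here means a stronger inhibitor, a higher number a weaker inhibitor
compound 2, `COc1cc[nH]c1/C=C1\C(=O)Nc2ccc([N+](=O)[O-])c(N3CC[C@@H](O)C3)c21`, gives 32 nM in this assay
compound 3, `COc1cc[nH]c1/C=C1\C(=O)Nc2ccc([N+](=O)[O-])c(N[C@H]3CC[C@H](N)C3)c21`, gives < 15 nM in this assay

For compound 1 the value is a limit of the measurement, not a number. For compound 3 the value is likewise a limit. Compound 3 therefore has no exact place among the three, but the step of an at least 2.1-fold lower number from compound 2 to compound 3 (0.32 log units; beyond the scatter) is at least modest, and the step of an at least 3.2-fold higher number from compound 1 to compound 2 (0.50 log units; beyond the scatter) points the other way. Compound 4, `COc1cc[nH]c1/C=C1\C(=O)Nc2ccc([N+](=O)[O-])c(N[C@H]3CC[C@H](O)C3)c21`, differs from compound 3 by hydroxy in place of amino on a saturated ring carbon. Among the measured compounds shown here, no measured step exchanges these two groups on the same ring; the two measured steps change the ring and its linkage. Compound 1 shows that a hydroxy group on a saturated ring is compatible with the limit (the limit of < 10 nM in this assay, at which 1 of the 3 values shown sits). The step of a number no lower from compound 3 to compound 4 (the limit leaves the size open) is expected to lie within the scatter. The estimate for compound 4 in this assay is 15 nM, between 5 nM and 50 nM.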

Compound 4, half-maximal inhibitory concentration: 339 nM
The estimate for compound 4 lay 23-fold (1.35 log units) below the measured number, and the stated range ends below it.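

In this assay, hydroxy in place of amino on the saturated ring carbon gives an at least 22-fold higher number from compound 3 to compound 4 (1.35 log units; beyond the scatter), so the two groups are not interchangeable at this place. A hydroxy group on a saturated ring does not by itself keep the number low: (3-hydroxycyclopentyl)amino gives an 11-fold higher number from compound 2 to compound 4 (1.03 log units; beyond the scatter) and an at least 33-fold higher number from compound 1 to compound 4 (1.53 log units; beyond the scatter). The values of compound 3 and compound 1 behind two of these steps are limits, not numbers. The compounds shown leave open whether a methylamino or a dimethylamino group on this ring carbon would keep the number of compound 3.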